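This account rests on a few compounds, and the source may have more. Where it says the series, first, only, none or still open, it means among the compounds named here.

Compound 1 `CCOc1ncc(-c2nc(C(F)(F)F)sc2N2CCN(C(=O)Cn3cnc4ccccc43)[C@H](C)C2)cn1`: 49 nM
Compound 2 `CCOc1ncc(-c2nc(C(F)(F)F)sc2N2CCN(C(=O)Cn3c(=O)oc4ccccc43)[C@H](C)C2)cn1`: 99 nM
Compound 3 `CCOc1ncc(-c2nc(C(F)(F)F)sc2N2CCN(C(=O)Cn3nccc3C)[C@H](C)C2)cn1`: 162 nM

These numbers come from a functional assay on U2OS cells for antagonist activity at C-X-C chemokine receptor type 3 (Homo sapiens), read by beta-arrestin recruitment; on this read-out lower numbers stand for stronger inhibition and higher numbers for weaker inhibition. Compound 3 gives the highest number of the three: the step of a 3.3-fold higher number from compound 1 to compound 3 (0.52 log units; beyond the scatter) lies beyond the scatter, while the step of a 1.6-fold higher number from compound 2 to compound 3 (0.21 log units; within the scatter) does not. Compound 4 `CCOc1ncc(-c2nc(C(F)(F)F)sc2N2CCN(C(=O)Cn3cc(Cl)cn3)[C@H](C)C2)cn1` differs from compound 3 in one place: 4-chloro-1H-pyrazol-1-yl in place of 5-methyl-1H-pyrazol-1-yl on a saturated chain carbon bound to a carbonyl carbon. Among the compounds with values here, none of the measured steps tests this exact swap; each of them exchanges the whole ring group, as in a 2.0-fold higher number from compound 1 to compound 2 (0.31 log units; beyond the scatter) and a 3.3-fold higher number from compound 1 to compound 3 (0.52 log units; beyond the scatter), rather than one substituent on the same five-membered ring. Within the data shown here, with no comparable step to lean on, no change beyond the scatter is expected for compound 4, so a 1.0-fold lower number from compound 3 to compound 4 (0.01 log units; within the scatter) is the estimated step. Compound 4 is expected to give about 160 nM in this assay, within 70 nM to 400 nM.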

Compound 4, half-maximal inhibitory concentration: 272 nM
Compound 4: middle estimate off by 1.7-fold (0.23 log units), on the low side; measured number inside the range.
By their numbers in this assay, from the lowest: compound 1; then compounds 2, 3 and 4 (each within the scatter of the next, the first and the last beyond it).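

In this assay, the first change made on the pyrazole ring itself, 4-chloro-1H-pyrazol-1-yl for 5-methyl-1H-pyrazol-1-yl, stays within the scatter (a 1.7-fold higher number from compound 3 to compound 4 (0.23 log units; within the scatter)). Compound 4 still falls clearly short of the groups with a fused benzene ring (a 2.7-fold higher number from compound 2 to compound 4 (0.44 log units; beyond the scatter); a 5.6-fold higher number from compound 1 to compound 4 (0.74 log units; beyond the scatter)), although compound 3 stays within the scatter of compound 2. Nothing available explains these differences.

On these data alone, this swap changes the substituent and its ring position together, so their separate contributions stay unknown. As far as these compounds go, how an amine such as morpholine would behave on this saturated chain carbon also remains open.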